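This account rests on a few compounds, and the source may have more. Where it says the series, first, only, none or still open, it means among the compounds named here.

Measured compounds in a functional assay on HL-60 cells (Homo sapiens) for inhibition, read by sulforhodamine B assay, with a stated time of 48 h, tested at 10 uM; a lower number here means less inhibition, a higher number more inhibition at the concentration tested (going by the name of the read-out):
compound 1 `Brc1ccc(-c2cn3ccnc3c(-c3ccc4ncn(C5CCCCC5)c4c3)n2)cc1` gives 23.2%
compound 2 `COc1ccccc1-c1cn2ccnc2c(-c2ccc3ncn(C4CCCCC4)c3c2)n1` gives 14.6%

Compound 2 has the lower of these two readings, but the step of a number 8.6 percentage points lower from compound 1 to compound 2 (within the scatter) stays within the scatter, so the two compounds cannot be told apart on this assay. Compound 3 `FC(F)(F)c1cccc(-c2cn3ccnc3c(-c3ccc4ncn(C5CCCCC5)c4c3)n2)c1` differs from compound 2 in one place: 3-(trifluoromethyl)phenyl in place of 2-methoxyphenyl on an aromatic carbon. Within the data shown here, the only measured step, a number 8.6 percentage points lower from compound 1 to compound 2 (within the scatter), also swaps one aryl group for another at the same position, and it did not move the number beyond the scatter. Among the measured compounds shown here, no measured step involves a 3-(trifluoromethyl)phenyl group, so nothing known here points to a change in either direction. The step of a number 5.4 percentage points higher from compound 2 to compound 3 (within the scatter) is therefore expected to stay within the scatter. On that basis compound 3 is estimated to give 20% in this assay, with a range from 5% to 40%.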

Compound 3, a percentage reported as inhibition, at one concentration (the size of the read-out at that concentration, not a potency): 1.06%
For compound 3 the middle estimate is 18.9 percentage points above the measured one; measured number below the stated range.
By their numbers in this assay, from the lowest: compound 3; then compounds 2 and 1 (each within the scatter of the next).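

In this assay, the group on this aromatic carbon now proves able to move the reading: 3-(trifluoromethyl)phenyl gives a number 13.5 percentage points lower from compound 2 to compound 3 (beyond the scatter) and also a number 22.1 percentage points lower from compound 1 to compound 3 (beyond the scatter). The earlier exchange between 4-bromophenyl and 2-methoxyphenyl stayed within the scatter, so this position does not treat all three aryl groups alike, with compound 3 set apart from the other two by steps of modest size. Nothing measured here offers an explanation for this drop.

The compounds shown leave open whether the drop belongs to the trifluoromethyl group itself or to where it sits on the phenyl ring, as the three rings differ in both substituent and its place. Also open, from the compounds shown here alone, is how a plain phenyl ring, an amine or a carboxylic acid at this position would read.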